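Swapping Phenylsulfonyl for Benzoyl in a Growth Inhibitor Series

The compounds below may be only part of what the source reports. "The series", "measured", "known", "first", "only" and "open" are said of these compounds alone.

Compound 1, `CC(=O)/C(=C\c1c(-c2ccccc2)[nH]c2ccccc12)S(=O)(=O)c1ccccc1`: 589 nM
Compound 2, `N#C/C(=C\c1c(-c2ccccc2)[nH]c2ccccc12)S(=O)(=O)c1ccccc1`: 595 nM

Of the compounds shown here, two have been measured in a functional assay on HT-29 cells (Homo sapiens) for inhibition, read by sulforhodamine B assay, with a stated time of 48 h; a lower number here means a stronger inhibitor of growth, a higher number a weaker inhibitor of growth. Compound 1, `CC(=O)/C(=C\c1c(-c2ccccc2)[nH]c2ccccc12)S(=O)(=O)c1ccccc1`, gives 589 nM. Compound 2, `N#C/C(=C\c1c(-c2ccccc2)[nH]c2ccccc12)S(=O)(=O)c1ccccc1`, gives 595 nM. Within the data shown here, compound 2 holds the highest of the two numbers, but its only neighbour is compound 1, and the step of a 1.0-fold higher number from compound 1 to compound 2 (0.00 log units; within the scatter) is within the scatter, so the two cannot be told apart.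

Compound 3, `N#C/C(=C\c1c(-c2ccccc2)[nH]c2ccccc12)C(=O)c1ccccc1`, has not yet been measured. It differs from compound 2 by benzoyl in place of phenylsulfonyl on a double-bonded chain carbon bound to a double-bonded chain carbon and a triple-bonded carbon. Among the measured compounds shown here, no measured step alters this group. For the measured compounds named here, the single measured step, a 1.0-fold higher number from compound 1 to compound 2 (0.00 log units; within the scatter), concerns the exchange of acetyl for cyano, not the phenylsulfonyl group, so it offers no direct precedent, only a hint that this chain tolerates alteration without a visible shift. Going by the values given here, with no relevant precedent, no step beyond the scatter is expected in either direction in this assay, though the uncertainty is wide. Compound 3 is therefore estimated at 600 nM, with a range of 200 nM to 2000 nM, which corresponds to an expected step of a 1.0-fold higher number from compound 2 to compound 3 (0.00 log units; within the scatter).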

Compound 3, concentration for 50% growth inhibition: 3400 nM
Beside the measured number, compound 3's estimate is 5.7-fold (0.75 log units) below it; the measured number lies above the stated range.
By their numbers in this assay, from the lowest: compounds 1 and 2 (each within the scatter of the next); then compound 3.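

In this assay, the group on this chain carbon turns out to matter: benzoyl in place of phenylsulfonyl gives a 5.7-fold higher number from compound 2 to compound 3 (0.76 log units; beyond the scatter), a modest step, and it means a weaker inhibitor of growth. The exchange of acetyl for cyano, which kept the phenylsulfonyl group in place, gave only a 1.0-fold higher number from compound 1 to compound 2 (0.00 log units; within the scatter), so a change at this chain can show up in the read-out even though that first one did not. Both phenylsulfonyl and benzoyl carry one six-membered aromatic ring of carbon only, so the step arises with that ring kept, and nothing available here explains what causes it.

The compounds shown leave open whether the phenylsulfonyl group's phenyl ring matters at all, which a methylsulfonyl group in the same place would begin to answer, and whether an amide would behave more like phenylsulfonyl or like benzoyl. They also leave open whether the step from phenylsulfonyl to benzoyl would be of similar size with acetyl rather than cyano on the chain, since it has been seen here only with cyano.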